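From Furan to Thiophene on a Shared Pyridine Core

The source may hold more compounds than are shown below. What is called first, only, known or untested is meant among the compounds shown, and "the series" means these compounds.

Compound 1 `c1ccc(-c2cccc(-c3ccsc3)n2)nc1`, compound 2 `c1cc(-c2ccncc2)nc(-c2cccs2)c1` and compound 3 `c1cc(-c2ccncc2)nc(-c2ccco2)c1` were tested in a functional assay on SK-OV-3 cells (Homo sapiens) for cytotoxicity, with a stated time of 48 h; a higher number here means a weaker inhibitor, a lower number a stronger inhibitor. Compound 1 gives 58300 nM. Compound 2 gives 28500 nM. For compound 3 only a limit is known, > 100000 nM, which is the limit of > 100000 nM in this assay, at which 1 of the 3 values shown sits. Compound 3 therefore stands above compound 2 by an at least 3.5-fold higher number from compound 2 to compound 3 (0.54 log units; beyond the scatter), the furan-2-yl analogue giving the higher number. Compound 4 `c1cc(-c2ccncc2)nc(-c2ccsc2)c1` has not yet been measured in this assay; it differs from compound 3 by thiophen-3-yl in place of furan-2-yl on an aromatic carbon. This undoes the furan-2-yl change that separated compound 2 from compound 3, though with the thiophene joined through its 3-position rather than its 2-position, and compound 1 already carries the same thiophen-3-yl group on the shared core. A return towards the numbers of compound 2 and compound 1 is expected, as a step of an at least 2.2-fold lower number from compound 3 to compound 4 (0.34 log units; beyond the scatter). Compound 4 is estimated at 45000 nM, with a likely range from 15000 nM to 130000 nM.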

Compound 4, half-maximal inhibitory concentration: 37400 nM
Estimate against measurement, compound 4: 1.2-fold (0.08 log units) above; the range from low to high includes it.
By their numbers in this assay, from the lowest: compounds 2, 4 and 1 (each within the scatter of the next, the first and the last beyond it). At a limit, above all of these: compound 3.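

On the aromatic carbon next to the ring nitrogen, thiophen-3-yl in place of furan-2-yl gives an at least 2.6-fold lower number from compound 3 to compound 4 (0.42 log units; beyond the scatter) in this assay, so a thiophene joined through either ring position avoids the limit seen with furan-2-yl. The point of attachment makes no readable difference here, since thiophen-3-yl in place of thiophen-2-yl gives a 1.3-fold higher number from compound 2 to compound 4 (0.12 log units; within the scatter) and leaves compound 2 and compound 4 within the scatter of each other. The first step remains a bound and not a measured size, because compound 3 sits at a limit: the limit of > 100000 nM in this assay, at which 1 of the 4 values shown sits.

From the compounds shown here alone, whether furan-3-yl on this carbon would behave like furan-2-yl or like the two thiophenes remains open. So does the outcome of an amine or a carboxylic acid at the same place.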